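Bromo to isopropoxy in the thioether series

The source may report more compounds than this note shows. Statements on the series, on what has been measured and on what is new or still open speak of the compounds shown alone.

In a functional assay on MCF7 cells (Homo sapiens) for inhibition, with a stated time of 48 h (on this read-out lower numbers stand for stronger inhibition and higher numbers for weaker inhibition), compound 1 (`COc1cc(Sc2c[nH]c3ccc(Br)cc23)cc(OC)c1OC`) gives 43 nM and so holds the higher number of the two measured compounds. Compound 2 (`COc1ccc2[nH]c(C)c(Sc3cc(OC)c(OC)c(OC)c3)c2c1`) gives 18 nM as the lower number, and the gap between them lies beyond the scatter. These two compounds differ in more than one place, so their gap cannot be assigned to any single change.

Compound 3 (`COc1cc(Sc2c[nH]c3ccc(OC(C)C)cc23)cc(OC)c1OC`) keeps the core of compound 1 and carries isopropoxy in place of bromo on an aromatic carbon. Going by the values given here, the counted difference is isopropoxy in place of bromo on an aromatic carbon and this is the only change. Among the compounds with values here, no measured pair isolates a swap of this kind, and no measured compound carries isopropoxy, so the expectation rests on judgement and its range is wide.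

The entering group is the larger one by the count, and a shift toward a higher number, meaning weaker inhibition, is expected beyond the scatter. The estimated step is a 2.8-fold higher number from compound 1 to compound 3 (0.45 log units; beyond the scatter) in this assay with little support from measured neighbours. Compound 3 is estimated at 120 nM with an expected range from 30 nM to 500 nM in this read-out.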

Compound 3, half-maximal inhibitory concentration: 1500 nM
The estimate for compound 3 lay 13-fold (1.10 log units) below the measured number; measured number outside the range, above it.
By their numbers in this assay, from the lowest: compound 2; then compound 1; then compound 3.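

Isopropoxy in place of bromo on an aromatic carbon gives a 35-fold higher number from compound 1 to compound 3 (1.54 log units; beyond the scatter) in this assay and is the first step in the series that can be tied to a single place. With the rest of compound 1 held fixed, this position proves far from indifferent: the change at this one aromatic carbon alone is enough to weaken inhibition strongly. The swap adds heavy atoms and a hydrogen-bond acceptor by the count, but no measurement here separates those differences or explains the size of the step.

One step cannot show whether the weakening follows from the oxygen attached to the ring, from the branched isopropyl part, or from the loss of bromine itself. Ethoxy, chloro or an amine at the same carbon on the core of compound 1 would bear on that question, and the present compounds leave open how far inhibition at this position can be retained with anything other than bromo.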